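This account rests on a few compounds, and the source may have more. Where it says the series, first, only, none or still open, it means among the compounds named here.

Measured in an assay on isolated protein with malate dehydrogenase, mitochondrial (Sus scrofa) as the target; on this read-out higher numbers stand for weaker inhibition and lower numbers for stronger inhibition:

Compound 1 `O=C(O)c1cnc2cc(OCc3c(Cl)c(Cl)c(Cl)c(Cl)c3Cl)ccc2c1O`: 4790 nM
Compound 2 `O=C(O)c1cnc2cc(OCc3cccc4ccccc34)ccc2c1O`: 13200 nM
Compound 3 `O=C(O)c1cnc2cc(S(=O)(=O)O)ccc2c1O`: 2140000 nM

Compound 3 stands at the highest number of the three in this assay; compound 2 is its nearest neighbour and compound 1 the furthest, and both gaps lie well beyond the usual scatter. The step to compound 4 `NS(=O)(=O)c1ccc2c(O)c(C(=O)O)cnc2c1` is a small one: amino in place of hydroxy on a sulfonyl sulfur. Going by the values given here, no pair of measured compounds shows this kind of exchange, so there is nothing to lean on for its size. With so little changed on the shared core, only a modest step is expected, and it is estimated as a 1.8-fold lower number from compound 3 to compound 4 (0.25 log units; within the scatter). Compound 4 is therefore estimated at 1200000 nM, within 300000 nM to 5000000 nM.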

Compound 4, half-maximal inhibitory concentration: 955000 nM
For compound 4 the middle estimate is 1.3-fold (0.10 log units) above the measured one, within the range that was stated.
By their numbers in this assay, from the lowest: compound 1; then compound 2; then compound 4; then compound 3.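

In this assay, going by these compounds alone, the exchange of sulfo for sulfamoyl gives a 2.2-fold lower number from compound 3 to compound 4 (0.35 log units; beyond the scatter) on the shared core, the first change on this sulfonyl sulfur that can be read. So replacing hydroxy with amino at this place moves the number by a modest step that lies beyond the scatter, while the count of hydrogen-bond donors stays the same. Nothing measured here explains that step. As far as these compounds go, it remains open how a methylamino or dimethylamino group on the same sulfur would compare with amino. From the compounds shown here alone, a longer chain carried on that amino nitrogen is equally open.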